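Three Compounds at the Assay Limit and a Fourth Expected There

This account rests on a few compounds, and the source may have more. Where it says the series, first, only, none or still open, it means among the compounds named here.

Compound 1, `COc1ccc(CNc2nc([SeH])nc3ccccc23)cc1`. In a functional assay on CCRF-CEM cells (Homo sapiens) for cytotoxicity, read by MTT assay, with a stated time of 72 h (a lower number here means that less compound is tolerated, a higher number that more compound is tolerated), compound 1 gives > 100000 nM, which is a limit of the assay and not a number.
Compound 2, `CSc1ccc(CNc2nc([SeH])nc3ccccc23)cc1`. In this assay compound 2 gives > 100000 nM, again a limit of the assay.
Compound 3, `COc1ccc(CNc2nc(SC)nc3ccccc23)cc1`. In this assay compound 3 gives > 100000 nM, also a limit of the assay.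

Compound 2 differs from compound 1 by one change, (methylsulfanyl in place of methoxy on an aromatic carbon), and the step it made in this assay is a step that the two limits leave unreadable from compound 1 to compound 2 because both values sit at the limit of > 100000 nM in this assay, at which 3 of the 3 values shown sit. Compound 3 differs from compound 1 in its core, (a group of 2 heavy atoms (1 carbon, 1 sulfur; no ring) in place of one selenium atom, on an aromatic carbon), and that step, a step that the two limits leave unreadable from compound 1 to compound 3, is equally unreadable. Compound 4, `CSc1ccc(CNc2nc(SC)nc3ccccc23)cc1`, has not yet been measured. It carries the core of compound 3 and differs from it by methylsulfanyl in place of methoxy on an aromatic carbon, the same change as from compound 1 to compound 2, at a place described in the same words. Compound 4 is expected to show a step of a number no higher from compound 3 to compound 4 (the limit leaves the size open), an expectation that rests on a step that the two limits leave unreadable from compound 1 to compound 2 and on compound 3 sitting at the limit of > 100000 nM in this assay, at which 3 of the 3 values shown sit. Compound 4 is therefore estimated to give 100000 nM in this assay, most likely reported only as a limit, with a range from 30000 nM to 300000 nM.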

Compound 4, concentration lethal to 50% of the cells: > 100000 nM
Compound 4 ended at the assay's limit; the forecaster's own chance of this, stated with the estimate: 85%; the middle value lies on the limit itself.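

In this assay compound 4 gives > 100000 nM and this is a limit of the assay, not a number. No new step can be read from compound 3 or compound 2 to compound 4, because all the values share one limit: the limit of > 100000 nM in this assay, at which 4 of the 4 values shown sit. The compounds shown leave open whether either change, methylsulfanyl for methoxy or the exchange at selenium, alters cytotoxicity at all.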